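This account rests on a few compounds, and the source may have more. Where it says the series, first, only, none or still open, it means among the compounds named here.

Measured in an ADME assay on microsomes from liver (Homo sapiens) for metabolic stability; on this read-out lower numbers stand for a shorter-lived compound and higher numbers for a longer-lived compound:
- compound 1 `CCC(CC)(c1nnc[nH]1)c1ccc(-c2ccc3cc(F)cc(F)c3c2)[nH]c1=O`: 1.76 h
- compound 2 `CCn1ncc2c(F)cc(-c3ccc(C(CC)(CC)c4nnc[nH]4)c(=O)[nH]3)cc21`: 2.7 h
- compound 3 `CC(C)C(c1ccc(-c2ccc3cccc(F)c3c2)[nH]c1=O)N1CCCCC1=O`: 0.183 h

Compound 3 has the lowest value of the three, and both other compounds stand above it by more than the scatter. Compound 1 and compound 2 lie within the scatter of each other.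

The next compound is compound 4 `CC(C)C(Cc1nnn[nH]1)c1ccc(-c2ccc3cccc(F)c3c2)[nH]c1=O`, which differs from compound 3 as follows: (1H-tetrazol-5-yl)methyl in place of 2-oxopiperidin-1-yl on a saturated chain carbon bound to an aromatic carbon and a saturated chain carbon. In words, this is (1H-tetrazol-5-yl)methyl in place of 2-oxopiperidin-1-yl on a saturated chain carbon bound to an aromatic carbon and a saturated chain carbon.

Going by the values given here, no measured pair differs in one place only, so no direct precedent exists for this change. Compound 1 at 1.76 h and compound 2 at 2.7 h both lack the 2-oxopiperidin-1-yl group, but they also differ from compound 3 elsewhere, so they offer only loose guidance. On that basis, the expected 4.9-fold higher number from compound 3 to compound 4 (0.69 log units; beyond the scatter) in this assay is upward and beyond the scatter, with considerable uncertainty. For compound 4 the estimated half-life is 0.9 h, with an expected range of 0.3 h to 3 h.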

Compound 4, half-life: > 3 h
Compound 4 ended at the assay's limit (the forecaster's own chance of this, stated with the estimate: 10%); at least 3.3-fold (0.52 log units) between middle value and limit.
By their numbers in this assay, from the lowest: compound 3; then compounds 1 and 2 (each within the scatter of the next). At a limit, above all of these: compound 4.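

Going by these compounds alone, on the saturated chain carbon bound to an aromatic carbon and a saturated chain carbon, the swap of 2-oxopiperidin-1-yl for (1H-tetrazol-5-yl)methyl gives in this assay an at least 16-fold higher number from compound 3 to compound 4 (1.21 log units; beyond the scatter), the first reading of a change in one place only. The half-life at this position therefore depends strongly on the group it carries, with the rest of the compound held constant. For compound 4, > 3 h is a limit of the assay, not a number: the limit of > 3 h in this assay, at which 1 of the 4 values shown sits.

The full size of the step stays open, and the compounds shown do not separate the contribution of the tetrazole ring from that of its methyl link. Also open, on these data alone, is how this assay would read with a carboxylic acid or a primary amine on the same carbon.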